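A few compounds are considered here, and "the series" means these few. Any claim that something is new, unique, unknown or untested is made for them only; others in the source may bear on it.

Working notes on the series. Compound 1 `COc1ccc(-n2cc(COc3ccc4oc(=O)ccc4c3)nn2)cc1` and compound 2 `O=c1ccc2cc(OCc3cn(-c4ccc(Cl)c(Cl)c4)nn3)ccc2o1` share a core and differ only in the aryl group on an aromatic nitrogen. In a functional assay on HCT-116 cells (Homo sapiens) for cytotoxicity, read by MTT assay, with a stated time of 48 h (a higher number here means a weaker inhibitor, a lower number a stronger inhibitor), compound 1 gives 37800 nM, and compound 2 gives 57300 nM. The step of a 1.5-fold higher number from compound 1 to compound 2 (0.18 log units; within the scatter) is the only measured one and lies within the scatter, so compound 2, though it holds the higher of the two numbers, is not separated from compound 1 by any real margin.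

Compound 3 `O=c1ccc2cc(OCc3cn(-c4ccccc4[N+](=O)[O-])nn3)ccc2o1` is the next member to be tested. Its change from compound 2 is 2-nitrophenyl in place of 3,4-dichlorophenyl on an aromatic nitrogen. Among the compounds with values here, the one step that bears on it, a 1.5-fold higher number from compound 1 to compound 2 (0.18 log units; within the scatter), shows that swapping the aryl group on this nitrogen left the read-out essentially unchanged, so no step beyond the scatter is expected in this assay. Compound 3 is therefore estimated to come out near 50000 nM, within 20000 nM to 125000 nM, an expected step of a 1.1-fold lower number from compound 2 to compound 3 (0.06 log units; within the scatter).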

Compound 3, half-maximal inhibitory concentration: 55800 nM
Compound 3: the middle estimate sits 1.1-fold (0.05 log units) below what was measured; measured number inside the range.
By their numbers in this assay, from the lowest: compounds 1, 3 and 2 (each within the scatter of the next).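

The 2-nitrophenyl group gives a third aryl substituent on the aromatic nitrogen, and in this assay it remains within the scatter of both earlier compounds (a 1.0-fold lower number from compound 2 to compound 3 (0.01 log units; within the scatter); a 1.5-fold higher number from compound 1 to compound 3 (0.17 log units; within the scatter)). Unlike 3,4-dichlorophenyl, the entering group contains nitrogen and oxygen and carries hydrogen-bond acceptors, yet across compounds 1, 2 and 3 these differences in the aryl group produce no step beyond the scatter at this position. No separate data bear on the reason for this flat read-out.

The compounds shown leave open whether a benzyl group, a longer alkyl chain or a phenyl ring carrying a carboxylic acid or an amine on this nitrogen would move the number beyond the scatter. They also leave open whether any change elsewhere on the shared core would do so.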